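A few compounds are considered here, and "the series" means these few. Any claim that something is new, unique, unknown or untested is made for them only; others in the source may bear on it.

Measured compounds in a functional assay on PC-3 cells (Homo sapiens) for cytotoxicity, read by sulforhodamine B assay; on this read-out higher numbers stand for weaker inhibition of growth and lower numbers for stronger inhibition of growth:
compound 1 `COc1cccc(OC)c1OCCNCCOc1ccccc1OCc1ccc(C)cc1`, 7800 nM;
compound 2 `COc1cccc(OC)c1OCCNCCOc1ccccc1OCc1ccccc1[N+](=O)[O-]`, 13200 nM;
compound 3 `COc1cccc(OC)c1OCCNCCOc1ccccc1OCc1cccc([N+](=O)[O-])c1`, 13200 nM.

Compound 3 sits together with compound 2 at the upper end of the three numbers, and compound 1 lies within the scatter of both, as the step of a 1.7-fold higher number from compound 1 to compound 3 (0.23 log units; within the scatter) shows.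

Compound 4 `COc1ccccc1COc1ccccc1OCCNCCOc1c(OC)cccc1OC` is not yet measured. Its difference from compound 3 is 2-methoxyphenyl in place of 3-nitrophenyl on a saturated chain carbon bound to an oxygen on an aromatic ring.

Within the data shown here, the steps that bear on this change are the earlier exchanges of the aryl group at the same place: a 1.7-fold higher number from compound 1 to compound 2 (0.23 log units; within the scatter), a 1.7-fold higher number from compound 1 to compound 3 (0.23 log units; within the scatter) and no change at the digits printed from compound 2 to compound 3 (within the scatter), all within the scatter. Among the measured compounds shown here, no step so far at this position has moved this assay beyond the scatter, so for compound 4 the expected step is a 1.3-fold lower number from compound 3 to compound 4 (0.12 log units; within the scatter), none beyond the scatter. Compound 4 is estimated at 10000 nM, with a range of 4000 nM to 25000 nM.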

Compound 4, concentration for 50% growth inhibition: 8900 nM
Compound 4: middle estimate off by 1.1-fold (0.05 log units), on the high side, within the range that was stated.
By their numbers in this assay, from the lowest: compounds 1, 4, 2 and 3 (each within the scatter of the next).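

In this assay, the 2-methoxyphenyl group at this place stays within the scatter of all three earlier aryl groups (a 1.5-fold lower number from compound 3 to compound 4 (0.17 log units; within the scatter); a 1.5-fold lower number from compound 2 to compound 4 (0.17 log units; within the scatter); a 1.1-fold higher number from compound 1 to compound 4 (0.06 log units; within the scatter)). Among these compounds, the methoxy-for-nitro exchange on an aromatic carbon, new to the series, therefore also leaves the number within the scatter, and no step among the four compounds goes beyond it. No supporting data bear on this result.

Open, going by these compounds, is whether an amine or a carboxylic acid on this ring, or a longer chain at this place, would give a step beyond the scatter.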